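Tert-butyl in place of phenyl: adenosine receptor binding notes

The compounds below may be only part of what the source reports. "The series", "measured", "known", "first", "only" and "open" are said of these compounds alone.

Measured compounds:
- compound 1 `O=C1CC(c2ccccc2)Cc2[nH]c(=O)c(C(=O)c3ccccc3)cc21`: 5%
- compound 2 `CC(=O)c1cc(S(=O)(=O)c2ccccc2)c(=O)[nH]c1C`: "not determined" (no result reported)
- compound 3 `O=C1CCCc2[nH]c(=O)c(S(=O)(=O)c3ccccc3)cc21`: 36%

In an assay on CHO cells for displacement of a labelled ligand from adenosine receptor A1 (Homo sapiens), tested at 10 uM (on this read-out higher numbers stand for more inhibition at the one concentration tested (going by the name of the read-out) and lower numbers for less inhibition), compound 1 gives 5%, the lowest of the two numbers reported. Compound 3 gives 36% in this assay, a result that lies beyond the scatter above that of compound 1. Among the measured compounds shown here, compound 2 has no number in this assay, so only two measured points describe the series, and no pair of them differs in one place only.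

Compound 4 `CC(C)(C)C(=O)c1cc2c([nH]c1=O)CC(c1ccccc1)CC2=O` has not been measured. It differs from compound 1 in a single place: tert-butyl in place of phenyl on a carbonyl carbon. For the measured compounds named here, no measured pair shows what exchanging benzoyl for (tert-butyl)carbonyl does here, so there is nothing to weigh the step against. Given the low starting point of compound 1 at 5%, a step of a number 5 percentage points higher from compound 1 to compound 4 (within the scatter) is expected for compound 4, small and not reliably beyond the scatter in either direction. For compound 4 an inhibition of 10% is estimated, with a likely range from 0% to 30%.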

Compound 4, a percentage reported as inhibition, at one concentration (the size of the read-out at that concentration, not a potency): 11%
For compound 4 the middle estimate is 1 percentage points below the measured one; the measured number falls inside the stated range.
By their numbers in this assay, from the lowest: compounds 1 and 4 (each within the scatter of the next); then compound 3.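

In this assay, among the compounds shown here, the exchange of phenyl for tert-butyl on a carbonyl carbon gives a number 6 percentage points higher from compound 1 to compound 4 (within the scatter), and this is the first pair that differs in one place only. It shows that, on the core of compound 1, a group with no ring and 4 heavy atoms reads the same within the scatter as the six-membered aromatic ring with 6 heavy atoms, so that at this position the aromatic ring is not needed to hold the result at this low level, though the pair cannot show what would raise it. No measurement at hand bears on why the two groups read alike.

For the compounds shown here, what an amine, a carboxylic acid or a longer chain such as n-hexyl would give on the same carbonyl carbon remains open, and with only this one pair, the position has so far been probed only at the low end of the read-out. Also open, as far as these compounds go, is whether tert-butyl in place of phenyl would read the same way on compound 3 , which gives 36% and so leaves more room for a change to show in either direction.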